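Shifting the halogen around the phenyl ring of compound 1

This account rests on a few compounds, and the source may have more. Where it says the series, first, only, none or still open, it means among the compounds named here.

Measured so far:
- compound 1, `O=C(NC1CCCC1)c1noc(-c2cccc(Cl)c2)c1Br`: 4220 nM
- compound 2, `O=C(NC1CCCC1)c1noc(-c2ccc(C(F)(F)F)cc2)c1F`: 112 nM

In a functional assay on CHO cells for antagonist activity at transient receptor potential cation channel subfamily V member 1 (Homo sapiens), read by fluorescence and calcium flux (a lower number here means a stronger inhibitor, a higher number a weaker inhibitor), compound 1 gives 4220 nM, the higher of the two numbers in hand. In this assay, within the data shown here, compound 2 gives 112 nM, a much lower number that lies beyond the scatter; compound 2 differs from compound 1 in two places, however, so the two values show only that the pair is far apart, not which change carries the gap.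

Compound 3, `O=C(NC1CCCC1)c1noc(-c2ccc(Br)cc2)c1Br`, has not yet been measured. It differs from compound 1 by 4-bromophenyl in place of 3-chlorophenyl on an aromatic carbon, with the bromo group on the shared core kept. Among the measured compounds shown here, no single-change step is in hand to set the size of this change, so the expectation rests on compound 2 alone. Since compound 2, which also carries its substituent in the 4-position of the phenyl ring, gives 112 nM, a moderate move to a lower number is expected from compound 1 to compound 3, a 4.7-fold lower number from compound 1 to compound 3 (0.67 log units; beyond the scatter), though with wide uncertainty. For compound 3 the estimate in this assay is 900 nM, with a range from 200 nM to 4500 nM.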

Compound 3, half-maximal inhibitory concentration: 410 nM
Estimate against measurement, compound 3: 2.2-fold (0.34 log units) above, and the stated range covers the measured number.
By their numbers in this assay, from the lowest: compound 2; then compound 3; then compound 1.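

In this assay, among these compounds, the change of aryl group alone gives a 10-fold lower number from compound 1 to compound 3 (1.01 log units; beyond the scatter) with the bromo group on the shared core kept, the first reading at this position from a single change. It shows that the aryl group on this aromatic carbon, next to the ring oxygen, can by itself shift the number by a large step, which the earlier pair, differing in two places, could not show. Nothing in hand explains this step.

The step changes both the halogen and its place on the phenyl ring, so the compounds shown do not tell which of the two carries it; 4-chlorophenyl and 3-bromophenyl at this position would separate them. Also open, as far as these compounds go, is how an aminophenyl group would read here, or a longer alkyl chain in place of the cyclopentyl group on the amide.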